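The compounds below may be only part of what the source reports. "The series", "measured", "known", "first", "only" and "open" are said of these compounds alone.

Compound 1 `COc1ccc(-c2ccc3c(c2)C(=O)C(=O)N3Cc2ccc(Cl)cc2)cc1`: 350 nM
Compound 2 `COc1ccc(-c2ccc3c(c2)C(=O)C(=O)N3Cc2cc(C)cc(C)c2)cc1`: 140 nM
Compound 3 `COc1ccc(CN2C(=O)C(=O)c3cc(-c4cc(OC)cc(OC)c4)ccc32)cc1`: 510 nM

In a functional assay on K562 cells (Homo sapiens) for antiproliferative activity, read by MTT assay, with a stated time of 48 h (on this read-out lower numbers stand for stronger inhibition and higher numbers for weaker inhibition), compound 3 gives the highest of the three numbers; compound 1 lies within the scatter of it, while compound 2 gives a clearly lower number. Compound 4 `COc1ccc(CN2C(=O)C(=O)c3cc(-c4ccc(C(F)(F)F)cc4)ccc32)cc1` differs from compound 3 by 4-(trifluoromethyl)phenyl in place of 3,5-dimethoxyphenyl on an aromatic carbon. Among the measured compounds shown here, the only measured step, a 2.5-fold lower number from compound 1 to compound 2 (0.40 log units; beyond the scatter), alters the group on the saturated chain carbon, not the aromatic carbon changed here, so it bears on this change only loosely: it shows that exchanging one aryl group for another can move the number modestly. With nothing measured at the aromatic position, compound 4 is expected to stay near compound 3, with a wide range. Compound 4 is estimated at 450 nM, between 150 nM and 1400 nM, an expected step of a 1.1-fold lower number from compound 3 to compound 4 (0.05 log units; within the scatter) within the scatter.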

Compound 4, half-maximal inhibitory concentration: 350 nM
The estimate for compound 4 lay 1.3-fold (0.11 log units) above the measured number; the range from low to high includes it.
By their numbers in this assay, from the lowest: compound 2; then compounds 1, 4 and 3 (each within the scatter of the next).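

Among the compounds shown here, the only step at this aromatic carbon of the shared core, 4-(trifluoromethyl)phenyl in place of 3,5-dimethoxyphenyl, gives in this assay a 1.5-fold lower number from compound 3 to compound 4 (0.16 log units; within the scatter) and so does not separate the two groups. The leaving group has 2 hydrogen-bond acceptors and the entering group 0, at 10 heavy atoms each, and this exchange of oxygen-bearing for fluorine-bearing substituents leaves the two numbers within the scatter of each other.

From the compounds shown here alone, whether an amine or a carboxylic acid on this aryl ring would behave the same remains open. Nothing given here accounts for the result.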